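The source may report more compounds than this note shows. Statements on the series, on what has been measured and on what is new or still open speak of the compounds shown alone.

Measured compounds:
- compound 1 `CO[C@]1(C)/C=C/C(=O)/C(CO)=C\C[C@](C)(CCC=C(C)C)/C=C/[C@H]1OC(=O)C=C(C)C`: 14300 nM
- compound 2 `CC(C)=CCC[C@]1(C)/C=C/[C@@H](OC(=O)C=C(C)C)[C@](C)(O)/C=C/C(=O)/C(CN(C)C)=C\C1`: 690 nM
- compound 3 `CC(C)=CCC[C@]1(C)/C=C/[C@@H](OC(=O)C=C(C)C)[C@](C)(O)CCC(=O)/C(CO)=C\C1`: > 40000 nM

In a functional assay on MCF7 cells (Homo sapiens) for antiproliferative activity, read by MTT assay, with a stated time of 48 h (on this read-out lower numbers stand for stronger inhibition and higher numbers for weaker inhibition), compound 2 gives the lowest of the two numbers shown; compound 1 sits well above it, beyond the usual scatter. Compound 3 reaches only the limit of this assay, (the limit of > 40000 nM in this assay, at which 1 of the 3 values shown sits), and gives no number. Compound 4 `CC(C)=CCC[C@]1(C)/C=C/[C@@H](OC(=O)C=C(C)C)[C@](C)(O)/C=C/C(=O)/C(CN=[N+]=[N-])=C\C1` is not yet measured; it differs from compound 2 in one place: azido in place of dimethylamino on a saturated chain carbon bound to a double-bonded ring carbon. Within the data shown here, no measured pair shows this same change, so the step is guessed. The change from compound 2 to compound 4 is expected to raise the number somewhat, likely beyond the scatter, as a 2.9-fold higher number from compound 2 to compound 4 (0.46 log units; beyond the scatter). Compound 4 is therefore estimated at 2000 nM, between 500 nM and 8000 nM.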

Compound 4, half-maximal inhibitory concentration: 4890 nM
The estimate for compound 4 lay 2.4-fold (0.39 log units) below the measured number; measured number inside the range.
By their numbers in this assay, from the lowest: compound 2; then compound 4; then compound 1. At a limit, above all of these: compound 3.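

In this assay, azido in place of dimethylamino on this saturated chain carbon gives a 7.1-fold higher number from compound 2 to compound 4 (0.85 log units; beyond the scatter), so the group at this position clearly affects the number. The two groups match in heavy atoms, hydrogen-bond donors and hydrogen-bond acceptors, yet their numbers differ, so those counts alone do not set the value here. Nothing measured here explains the size of this step.

From the compounds shown here alone, whether a primary amine or a carboxylic acid at this position would give a number closer to that of compound 2 or compound 4 remains open.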